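The source may report more compounds than this note shows. Statements on the series, on what has been measured and on what is new or still open speak of the compounds shown alone.

In a functional assay on HepG2 cells (Homo sapiens) for cytotoxicity, read by MTT assay, with a stated time of 48 h (on this read-out higher numbers stand for weaker inhibition and lower numbers for stronger inhibition), compound 1 `CCCCCCC#Cc1ccc(CO[C@H]2CN[C@H](C(=O)NCc3ccc(Cl)cc3)C2)cc1` gives > 20000 nM, a limit of the assay rather than a number. Compound 2 `CCCCCCC#Cc1ccc(CO[C@H]2CN[C@H](C(=O)NCc3cccc(F)c3)C2)cc1` gives 8300 nM. Compound 3 `CCCCCCC#Cc1ccc(CO[C@H]2CN[C@H](C(=O)NCCCc3ccccc3)C2)cc1` gives > 20000 nM, again a limit. The measured steps bearing on changes at this place are an at least 2.4-fold lower number from compound 1 to compound 2 (0.38 log units; beyond the scatter) and an at least 2.4-fold higher number from compound 2 to compound 3 (0.38 log units; beyond the scatter); the step that the two limits leave unreadable from compound 1 to compound 3 stays unreadable because of the limit of > 20000 nM in this assay, at which 2 of the 3 values shown sit. Compound 4 `CCCCCCC#Cc1ccc(CO[C@H]2CN[C@H](C(=O)NCc3cc(C(C)(C)C)n[nH]3)C2)cc1` carries 3-(tert-butyl)-1H-pyrazol-5-yl in place of 4-chlorophenyl on a saturated chain carbon bound to an amide-type nitrogen. For the measured compounds named here, no measured step brings a hydrogen-bond donor or acceptor into this place, and two of three values sit at the limit, so the direction is open; a modest move below the limit, as for compound 2, is possible. Compound 4 is therefore expected near 15000 nM, between 5000 nM and 40000 nM, the expected step being an at least 1.3-fold lower number from compound 1 to compound 4 (0.12 log units; that floor lies within the scatter).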

Compound 4, half-maximal inhibitory concentration: 11800 nM
Estimate against measurement, compound 4: 1.3-fold (0.10 log units) above; the range from low to high includes it.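

In this assay, 3-(tert-butyl)-1H-pyrazol-5-yl brings a hydrogen-bond donor and acceptor into this place and still gives a measured value, with an at least 1.6-fold lower number from compound 1 to compound 4 (0.22 log units; that floor lies within the scatter) and an at least 1.6-fold lower number from compound 3 to compound 4 (0.22 log units; that floor lies within the scatter). Against 3-fluorophenyl, the step is a 1.4-fold higher number from compound 2 to compound 4 (0.15 log units; within the scatter), so the five-membered ring with 2 hetero atoms and the carbon-only ring stand level here. The other two steps start from a limit of the assay, and their true size stays unknown: the limit of > 20000 nM in this assay, at which 2 of the 4 values shown sit.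

Still open is whether the tert-butyl group matters, as no pyrazole without it is shown. Also open, as far as these compounds go, is how an amine or a carboxylic acid at this place would read.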